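The compounds below may be only part of what the source reports. "The series", "measured", "known", "first", "only" and "open" are said of these compounds alone.

Measured compounds:
compound 1, `Clc1ccc(N2N=NCC2c2ccncc2)cc1`: 257 mg/kg
compound 2, `COc1ccc(-n2nncc2-c2ccncc2)cc1`: 311 mg/kg

Both were tested in a functional assay on the whole organism with Mus musculus as the target, in the maximal electroshock model; on this read-out higher numbers stand for an effect only at larger amounts of compound and lower numbers for an effect already at smaller amounts. Compound 2 gives 311 mg/kg, the higher of the two numbers shown, but compound 1 with 257 mg/kg lies within the scatter of it, so the two cannot be told apart on this read-out. Compound 3, `c1ccc(-n2nncc2-c2ccncc2)cc1`, has not yet been measured. Against compound 2 the change is hydrogen in place of methoxy on an aromatic carbon. For the measured compounds named here, no pair of measured compounds differs in just this way, so nothing here tells how large such a step is. With the two known values sitting so close together, the expected step, a 1.0-fold lower number from compound 2 to compound 3 (0.02 log units; within the scatter), is one that stays within the scatter, in no particular direction. Compound 3 is therefore estimated at 300 mg/kg, with a range from 150 mg/kg to 600 mg/kg.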

Compound 3, dose for half-maximal effect: 78.8 mg/kg
Estimate against measurement, compound 3: 3.8-fold (0.58 log units) above; the whole stated range lies above it.
By their numbers in this assay, from the lowest: compound 3; then compounds 1 and 2 (each within the scatter of the next).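

In this assay, hydrogen in place of methoxy gives a 3.9-fold lower number from compound 2 to compound 3 (0.60 log units; beyond the scatter), the first change in a single place among these compounds. It shows that the group on this aromatic carbon, para to a large group, affects the dose needed: without the methoxy group, an effect appears at smaller amounts of compound. Nothing available explains why this step occurs.

Whether other groups at this position would also shift the dose remains open, as a methyl group or an amine is not among the compounds shown, so one step cannot show whether hydrogen is the best choice here. Compound 1 differs from compound 3 in more than one place, so it cannot settle what a chlorine atom does at this position.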